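Phenoxy series: from compound 3 to compound 4

The source may report more compounds than this note shows. Statements on the series, on what has been measured and on what is new or still open speak of the compounds shown alone.

In a physicochemical assay for lipophilicity, measured as chromatographic lipophilicity, at pH 7.4 (on this read-out higher numbers stand for higher lipophilicity and lower numbers for lower lipophilicity), compound 1 `COc1cc(-c2nnc3n2CCCC3(c2ccc(F)c(F)c2)C(C)(C)O)ccc1-c1cnc(C)o1` gives 2.9, compound 2 `COc1cc(-c2nnc3n2CCCC3(Oc2ccc(F)c(F)c2)C(C)(C)O)ccc1-c1cnc(C)o1` gives 2.8 and compound 3 `COc1cc(-c2nnc3n2CCCC3(Oc2ccc(F)c(Cl)c2)C(C)(C)O)ccc1-c1cnc(C)o1` gives 3.2. The only gap beyond the scatter among these three is a number 0.40 log units higher from compound 2 to compound 3 (beyond the scatter). The other two, a number 0.10 log units lower from compound 1 to compound 2 (within the scatter) and a number 0.30 log units higher from compound 1 to compound 3 (within the scatter), stay within it, so compound 3 stands apart from compound 2 only.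

Next in line is compound 4 `COc1cc(-c2nnc3n2CCCC3(Oc2cc(F)c(F)c(F)c2)C(C)(C)O)ccc1-c1cnc(C)o1`. The change is 3,4,5-trifluorophenyl in place of 3-chloro-4-fluorophenyl on an oxygen on a saturated carbon, or 3-chloro-4-fluorophenoxy to 3,4,5-trifluorophenoxy.

The closest evidence is the pair that differs by chloro and fluoro on an aromatic carbon, a number 0.40 log units higher from compound 2 to compound 3 (beyond the scatter), which compound 4 partly reverses by losing the chloro. Going by the values given here, compound 4 also carries one more fluoro than compound 2, and no measured pair isolates that addition. The steps from compound 1 concern the phenyl to phenoxy exchange and say little here.

A lower number is therefore expected, slightly smaller in size than the reverse of the chloro step, and the estimated step is a number 0.30 log units lower from compound 3 to compound 4 (within the scatter). The estimate for compound 4 is 2.9, with an expected range from 2.6 to 3.2.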

Compound 4, distribution coefficient: 3.2
Compound 4: the middle estimate sits 0.30 log units below what was measured; low and high end bracket the measured number.
By their numbers in this assay, from the lowest: compounds 2, 1, 3 and 4 (each within the scatter of the next, the first and the last beyond it).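

In this assay, 3,4,5-trifluorophenoxy in place of 3-chloro-4-fluorophenoxy reads no change at the digits printed from compound 3 to compound 4 (within the scatter), so at this position on an oxygen on a saturated carbon, removal of the chloro does not simply undo the earlier chloro step. Going by these compounds alone, the first step to isolate fluoro in place of hydrogen on an aromatic carbon reads a number 0.40 log units higher from compound 2 to compound 4 (beyond the scatter), matching in size the chloro step, a number 0.40 log units higher from compound 2 to compound 3 (beyond the scatter), so two different single changes on compound 2 arrive at the same printed number. Against the directly attached 3,4-difluorophenyl of the core of compound 1, the new phenoxy group reads a number 0.30 log units higher from compound 1 to compound 4 (within the scatter), which leaves that exchange as unresolved as it was with compound 2 and compound 3.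

Nothing at hand accounts for the equal size of the chloro and fluoro steps. Still open is how the number responds when an amine, a carboxylic acid or a longer chain replaces the halogens on the phenoxy ring, since all the groups shown at this position carry only fluoro or chloro.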